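The compounds below may be only part of what the source reports. "The series", "measured", "known", "first", "only" and "open" are said of these compounds alone.

Compound 3 `Cc1ccc(C)c(/C=C(\C(=O)c2ccc(Cl)cc2)S(=O)(=O)Cc2ccc(Cl)cc2)c1` gives 10000 nM in a functional assay on DU-145 cells (Homo sapiens) for inhibition, read by trypan blue exclusion, with a stated time of 96 h; on this read-out higher numbers stand for weaker inhibition of growth and lower numbers for stronger inhibition of growth. Among the compounds with values here, that number is level with the one for compound 1 `CSc1ccc(/C=C(\C(=O)c2ccc(Cl)cc2)S(=O)(=O)Cc2ccc(Cl)cc2)cc1`, which in this assay gives 10000 nM; together these two stand at the highest of the three numbers. Compound 2 `Cc1ccc(/C=C(\C(=O)c2ccc(Cl)cc2)S(=O)(=O)Cc2ccc(Cl)cc2)s1` is the one set apart: in this assay compound 2 gives 1000 nM. The steps that separate these three compounds all alter the group on the double-bonded chain carbon: a 10-fold lower number from compound 1 to compound 2 (1.00 log units; beyond the scatter), no change at the digits printed from compound 1 to compound 3 (within the scatter) and a 10-fold higher number from compound 2 to compound 3 (1.00 log units; beyond the scatter).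

Compound 4 `Cc1ccc(S(=O)(=O)/C(=C/c2cc(C)ccc2C)C(=O)c2ccc(Cl)cc2)cc1` differs from compound 3 at another place, on the sulfonyl sulfur: 4-methylphenyl in place of 4-chlorobenzyl on a sulfonyl sulfur. Within the data shown here, no measured pair changes the group on the sulfonyl sulfur, so none of the three steps bears directly on this change, and the measured numbers give no guidance on whether a change there would move the number up or down. The expectation is therefore a step of no change at the digits printed from compound 3 to compound 4 (within the scatter) of no size beyond the scatter, with a range wide enough to leave room for a shift in either direction. For compound 4 the estimate in this assay is 10000 nM, with a range from 3000 nM to 30000 nM.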

Compound 4, concentration for 50% growth inhibition: 1000 nM
Beside the measured number, compound 4's estimate is 10-fold (1.00 log units) above it; measured number outside the range, below it.
By their numbers in this assay, from the lowest: compounds 2 and 4 (each within the scatter of the next); then compounds 1 and 3 (each within the scatter of the next).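

Within the data shown here, the step of a 10-fold lower number from compound 3 to compound 4 (1.00 log units; beyond the scatter) in this assay shows that the group on the sulfonyl sulfur can move the number beyond the scatter, which the earlier compounds could not show, since all three carry 4-chlorobenzyl there and differ only on the double-bonded chain carbon. The change also gives stronger inhibition of growth with a swap that leaves the count of hydrogen-bond donors and acceptors, the net charge and the six-membered aromatic ring of carbon as they were, though two things alter at once: the benzyl becomes a phenyl directly on the sulfonyl sulfur, and chlorine gives way to methyl. Nothing at hand explains why this swap moves the number.

The compounds shown cannot separate those two alterations, and a 4-chlorophenyl or a 4-methylbenzyl group on the sulfonyl sulfur would be the direct way to tell them apart. Going by these compounds, it also remains open whether 4-methylphenyl would move the number in the same way on compound 2, which carries 5-methylthiophen-2-yl on the double-bonded chain carbon.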